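Aryl substituent changes on the shared core: toward compound 4

A few compounds are considered here, and "the series" means these few. Any claim that something is new, unique, unknown or untested is made for them only; others in the source may bear on it.

Measured so far in an assay on HEK293T cells for antagonist activity at transient receptor potential cation channel subfamily M member 8 (Homo sapiens), read by fluorescence and calcium flux, with a stated time of 60 min; on this read-out higher numbers stand for weaker inhibition and lower numbers for stronger inhibition:
Compound 1 `C[C@H](c1cc(F)c(F)c(F)c1)N(C(=O)c1ccccc1)[C@@H](C(N)=O)c1ccccc1` gives 1700 nM.
Compound 2 `C[C@H](c1cc(F)cc(F)c1F)N(C(=O)c1ccccc1)[C@@H](C(N)=O)c1ccccc1` gives 2200 nM.
Compound 3 `Cc1c(F)cc(F)cc1[C@@H](C)N(C(=O)c1ccccc1)[C@@H](C(N)=O)c1ccccc1` gives 2000 nM.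

On the numbers shown, compound 3 sits second of three, yet within the scatter of both others: a 1.2-fold higher number from compound 1 to compound 3 (0.07 log units; within the scatter), and a 1.1-fold lower number from compound 2 to compound 3 (0.04 log units; within the scatter).

Compound 4 `C[C@H](c1ccccc1)N(C(=O)c1ccccc1)[C@@H](C(N)=O)c1ccccc1` differs from compound 3 by phenyl in place of 3,5-difluoro-2-methylphenyl on a saturated chain carbon bound to an amide-type nitrogen and a saturated chain carbon. Within the data shown here, the steps that bear on this are those that rearrange the substituents on the same ring: a 1.3-fold higher number from compound 1 to compound 2 (0.11 log units; within the scatter), a 1.2-fold higher number from compound 1 to compound 3 (0.07 log units; within the scatter) and a 1.1-fold lower number from compound 2 to compound 3 (0.04 log units; within the scatter). Each stays within the scatter, so shifting fluoro and methyl about this ring left this assay unchanged. Stripping the ring bare reaches beyond any measured step, and no step covers that directly. No change beyond the scatter is therefore expected. Compound 4 is estimated at 2500 nM, with a range from 1000 nM to 7000 nM, which would mean an expected step of a 1.3-fold higher number from compound 3 to compound 4 (0.10 log units; within the scatter).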

Compound 4, half-maximal inhibitory concentration: 1200 nM
For compound 4 the middle estimate is 2.1-fold (0.32 log units) above the measured one, and the stated range covers the measured number.
By their numbers in this assay, from the lowest: compounds 4, 1, 3 and 2 (each within the scatter of the next).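

In this assay, the bare phenyl stays within the scatter of all three substituted rings at this position: a 1.7-fold lower number from compound 3 to compound 4 (0.22 log units; within the scatter), a 1.8-fold lower number from compound 2 to compound 4 (0.26 log units; within the scatter) and a 1.4-fold lower number from compound 1 to compound 4 (0.15 log units; within the scatter). The fluoro and methyl groups on these rings are thus not required for this level of inhibition on the shared core, which the earlier rearrangements of those groups could not show. Nothing available explains this result. Still open, from the compounds shown here alone, is whether an amine or a carboxylic acid on this ring would give a step beyond the scatter.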